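The source may report more compounds than this note shows. Statements on the series, on what has been measured and on what is new or still open speak of the compounds shown alone.

Measured compounds:
- compound 1 `C=C(C)CCOC(=O)C[C@@H]1C(C(=O)OC)=CO[C@@H](O[C@@H]2O[C@H](CO)[C@@H](O)[C@H](O)[C@H]2O)/C1=C/C`: in a functional assay on SK-BR-3 cells (Homo sapiens) for antiproliferative activity, read by MTT assay, with a stated time of 72 h (on this read-out higher numbers stand for weaker inhibition and lower numbers for stronger inhibition), compound 1 reaches only the limit of the assay, > 15000 nM.
- compound 2 `C/C=C1/[C@H](O[C@@H]2O[C@H](COC(C)=O)[C@@H](OC(C)=O)[C@H](OC(C)=O)[C@H]2OC(C)=O)OC=C(C(=O)OC)[C@H]1CC(=O)O`: in this assay compound 2 likewise gives a limit, > 15000 nM.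
- compound 3 `C/C=C1/[C@H](O[C@@H]2O[C@H](COC(C)=O)[C@@H](OC(C)=O)[C@H](OC(C)=O)[C@H]2OC(C)=O)OC=C(C(=O)OC)[C@H]1CC(=O)OCCC1CCCCC1`: in this assay compound 3 gives a limit, > 15000 nM.

Compound 1 therefore stands nowhere in particular among the numbers shown: its result is a limit, and the two other results are limits of the same kind, so no ordering among the three is possible. Going by the values given here, the only single-point change among measured compounds is a step that the two limits leave unreadable from compound 2 to compound 3, and because both ends sit at the limit of > 15000 nM in this assay, at which 3 of the 3 values shown sit, its size cannot be read; the acetylated sugar of compounds 2 and 3 also sets them apart from compound 1, whose sugar carries free hydroxyl groups.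

The unmeasured compound 4 `C/C=C1/[C@H](O[C@@H]2O[C@H](CO)[C@@H](O)[C@H](O)[C@H]2O)OC=C(C(=O)OC)[C@H]1CC(=O)OCCc1ccccc1` differs from compound 1 by phenyl in place of 1-methylethenyl on a saturated chain carbon, two bonds along the chain from an oxygen next to a carbonyl group. Among the compounds with values here, no measured step bears on this change. In this assay the expectation for compound 4 is that the read-out again ends at the limit, so the step that the limit leaves unreadable from compound 1 to compound 4 is expected to be unreadable rather than a real shift. The estimate for compound 4 is 20000 nM, within a range from 7000 nM to 60000 nM.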

Compound 4, half-maximal inhibitory concentration: 11000 nM
The estimate for compound 4 lay 1.8-fold (0.26 log units) above the measured number, within the range that was stated.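

Compound 4 is the only compound shown that gives a number rather than a limit in this assay, at 11000 nM, so this place on the ester chain can carry a group that brings the read-out within the measurable range while the sugar keeps its free hydroxyl groups. Phenyl in place of 1-methylethenyl, on a saturated chain carbon, two bonds along the chain from an oxygen next to a carbonyl group, gives an at least 1.3-fold lower number from compound 1 to compound 4 (0.13 log units; that floor lies within the scatter), so the printed floor alone does not establish a real gain, and the upper size of the step cannot be read. The number for compound 4 stands alone in the set, and no trend can yet be drawn from it: the limit of > 15000 nM in this assay, at which 3 of the 4 values shown sit.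

Going by these compounds alone, the single step leaves open whether the change in read-out follows from the aromatic ring itself or simply from the extra heavy atoms, and the acetylated sugar of compound 3 keeps that compound from answering the question. As far as these compounds go, how an amine on the phenyl ring, a longer chain carrying the phenyl, or a carboxylic acid at the chain end would read in this assay also remains open.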